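The source may hold more compounds than are shown below. What is called first, only, known or untested is meant among the compounds shown, and "the series" means these compounds.

Compound 1 `COc1cc2ncnc(N3CCc4ccccc43)c2cc1NC(=O)/C=C/C(C)C` belongs to a small set of three related compounds tested in a functional assay on PC-3 cells (Homo sapiens) for antiproliferative activity, read by MTT assay, with a stated time of 72 h; a lower number here means a stronger inhibitor, a higher number a weaker inhibitor. In this assay compound 1 gives 6530 nM, the lowest of the three numbers, although the other two lie within the scatter of it. Compound 2 `CC(C)/C=C/C(=O)Nc1cc2c(N3CCc4ccccc43)ncnc2cc1O[C@@H]1CCOC1` gives 11200 nM, a change of a 1.7-fold higher number from compound 1 to compound 2 (0.23 log units; within the scatter). Compound 3 `COc1cc2ncnc(N3CCCc4ccccc43)c2cc1NC(=O)/C=C/C(C)C` gives 8430 nM, a change of a 1.3-fold higher number from compound 1 to compound 3 (0.11 log units; within the scatter). Both of these steps alter a part of the molecule away from the acrylamide tail, and neither moves the number beyond the scatter.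

Compound 4 `COc1cc2ncnc(N3CCc4ccccc43)c2cc1NC(=O)/C=C/CN1CCN(C)CC1` is not yet measured. It differs from compound 1 at the far end of that tail: (4-methylpiperazin-1-yl)methyl in place of isopropyl on a double-bonded chain carbon bound to a double-bonded chain carbon. Among the compounds with values here, no measured step touches this position, so the two steps above give no direct guide; they show only that modest changes elsewhere left the number roughly where it was. With no evidence either way, the expectation is that compound 4 stays near compound 1, so the expected step is a 1.3-fold lower number from compound 1 to compound 4 (0.12 log units; within the scatter), well within the scatter, and with a wide uncertainty. The estimate for compound 4 in this assay is 5000 nM, with a plausible range from 1000 nM to 25000 nM.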

Compound 4, half-maximal inhibitory concentration: 9180 nM
The estimate for compound 4 lay 1.8-fold (0.26 log units) below the measured number; the measured number falls inside the stated range.
By their numbers in this assay, from the lowest: compounds 1, 3, 4 and 2 (each within the scatter of the next).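

Within the data shown here, compound 4 gives the first reading at the far end of the tail, where the small isopropyl is replaced by the larger (4-methylpiperazin-1-yl)methyl, which brings in a six-membered non-aromatic ring with 2 hetero atoms. In this assay this exchange gives a 1.4-fold higher number from compound 1 to compound 4 (0.15 log units; within the scatter), so even a substantial change in size and make-up at this position leaves the number where repeated measurements could have placed it, as the two changes elsewhere on the molecule also did. No measurement shown here offers an explanation for this outcome.

Going by these compounds, with only isopropyl and (4-methylpiperazin-1-yl)methyl compared at this position, a single exchange cannot show how far this tolerance extends, and it remains open whether a dimethylaminomethyl group, a morpholin-4-ylmethyl group, a carboxylic acid or a longer carbon chain would also leave the number within the scatter. Also open, on these data alone, is whether any change to the tail can move the number clearly beyond the scatter in this assay, and whether the (4-methylpiperazin-1-yl)methyl group would behave the same way on a compound carrying the oxolan-3-yl or 1,2,3,4-tetrahydroquinolin-1-yl group.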